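The source may hold more compounds than are shown below. What is called first, only, known or untested is meant among the compounds shown, and "the series" means these compounds.

In an ADME assay on microsomes from liver (Homo sapiens) for metabolic stability, read by LC-MS, using NADPH, with stated times of 5 min and 30 min, tested at 1 uM (a lower number here means slower removal, a higher number faster removal of the compound), compound 1 `Cc1nccn1-c1cnc(NCc2c(F)ccc3c2CCO3)c2cn[nH]c(=O)c12` gives 8 mL.min-1.g-1 and compound 3 `Cc1cc(-c2cnc(NCc3c(F)ccc4c3CCO4)c3cn[nH]c(=O)c23)n(C)n1` gives 24 mL.min-1.g-1 while compound 2 `Cc1nc(CN(C)C)ccc1-c1cnc(NCc2c(F)ccc3c2CCO3)c2cn[nH]c(=O)c12` gives 13 mL.min-1.g-1 and so stands within the scatter of both others. Compound 4 `Cc1nc(C(=O)N(C)C)ccc1-c1cnc(NCc2c(F)ccc3c2CCO3)c2cn[nH]c(=O)c12` differs from compound 2 by dimethylcarbamoyl in place of (dimethylamino)methyl on an aromatic carbon and thus has dimethylcarbamoyl in place of (dimethylamino)methyl on an aromatic carbon. For the measured compounds named here, no measured step changes this group alone. Going by the values given here, the nearest evidence is exchange of the whole aromatic group on the shared core, namely a 1.6-fold higher number from compound 1 to compound 2 (0.21 log units; within the scatter) and a 1.8-fold higher number from compound 2 to compound 3 (0.27 log units; within the scatter) and also a 3.0-fold higher number from compound 1 to compound 3 (0.48 log units; beyond the scatter) as the one modest step. No step beyond the scatter is therefore expected in this assay for this smaller change. The expected step is a 1.1-fold higher number from compound 2 to compound 4 (0.03 log units; within the scatter) and so lies within the scatter. Compound 4 is estimated at 14 mL.min-1.g-1 with an expected range from 7 mL.min-1.g-1 to 28 mL.min-1.g-1 in this measurement.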

Compound 4, intrinsic clearance in microsomes: 19 mL.min-1.g-1
Beside the measured number, compound 4's estimate is 1.4-fold (0.13 log units) below it, within the range that was stated.
By their numbers in this assay, from the lowest: compounds 1, 2, 4 and 3 (each within the scatter of the next, the first and the last beyond it).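

In this assay the exchange of (dimethylamino)methyl for dimethylcarbamoyl gives a 1.5-fold higher number from compound 2 to compound 4 (0.16 log units; within the scatter) and is the first step shown that changes this group alone, with the rest of compound 2 kept. At this place, on an aromatic carbon next to the ring nitrogen, the added carbonyl thus leaves the number within the scatter. Nothing measured here bears on why this is so. As far as these compounds go, it remains open whether a carboxylic acid, a cyclic amine such as morpholine or a longer chain at this place would give a step beyond the scatter.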